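The source may hold more compounds than are shown below. What is called first, only, known or untested is meant among the compounds shown, and "the series" means these compounds.

Compound 1 `COc1ccc(-n2nncc2CN2C(=O)C3(C(C#N)=C(N)Oc4c3c3nc5ccccc5nc3c3ccccc43)c3ccccc32)cc1` and compound 2 `N#CC1=C(N)Oc2c(N)cc3nc4ccccc4nc3c2C12C(=O)N(Cc1cnnn1-c1ccc(Cl)cc1)c1ccccc12` share a large part of their core. In a functional assay on HCT-116 cells (Homo sapiens) for antiproliferative activity, read by MTT assay, with a stated time of 48 h (on this read-out lower numbers stand for stronger inhibition and higher numbers for weaker inhibition), compound 1 gives only a limit of the assay, > 50000 nM. In this assay compound 2 likewise returns a limit, > 50000 nM. Compound 2 thus stands at the limit of > 50000 nM in this assay, at which 2 of the 2 values shown sit, with no number behind it. Compound 3 `CCc1cccc(CC)c1-n1nncc1CN1C(=O)C2(C(C#N)=C(N)Oc3c(N)cc4nc5ccccc5nc4c32)c2ccccc21` arises from compound 2 through one change: 2,6-diethylphenyl in place of 4-chlorophenyl on an aromatic nitrogen. Within the data shown here, no measured pair shows what this swap does here. Compound 3 is expected to stay at the limit, a step of a number no higher from compound 2 to compound 3 (the limit leaves the size open) of no size beyond the scatter. The estimate for compound 3 is 50000 nM, between 20000 nM and 150000 nM.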

Compound 3, half-maximal inhibitory concentration: 37600 nM
The estimate for compound 3 lay 1.3-fold (0.12 log units) above the measured number, and the stated range covers the measured number.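

In this assay, among these compounds, compound 3 gives 37600 nM, the first measured number in this set rather than a limit. As far as these compounds go, the swap of 4-chlorophenyl for 2,6-diethylphenyl on the aromatic nitrogen is an at least 1.3-fold lower number from compound 2 to compound 3 (0.12 log units; that floor lies within the scatter), so the true size of the step stays unknown and activity at this position remains weak. The read-out here is still dominated by a ceiling: the limit of > 50000 nM in this assay, at which 2 of the 3 values shown sit.

From the compounds shown here alone, whether an amine or a carboxylic acid on this phenyl ring, or longer chains in place of the ethyl groups, would lower the number further remains open. So does whether 2,6-diethylphenyl would give a measurable number on the core of compound 1.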